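The source may report more compounds than this note shows. Statements on the series, on what has been measured and on what is new or still open speak of the compounds shown alone.

Compound 1 `Cc1cc(C)c(Oc2cc(Nc3ccc(C#N)cc3)ncc2C(=O)NCc2cn(Cc3cccc(F)c3)nn2)c(C)c1`: in an ADME assay on MT4 cells (Homo sapiens) for cytotoxicity, read by MTT assay, with a stated time of 5 days (on this read-out higher numbers stand for lower toxicity in this test and lower numbers for higher toxicity in this test), compound 1 gives >= 204000 nM, which is a limit of the assay and not a measured number.
Compound 2 `CCOC(=O)CCn1cc(CNC(=O)c2cnc(Nc3ccc(C#N)cc3)cc2Oc2c(C)cc(C)cc2C)nn1`: compound 2 gives 21500 nM.
Compound 3 `Cc1cc(C)c(Oc2cc(Nc3ccc(C#N)cc3)ncc2C(=O)NCc2cn(CCC#N)nn2)c(C)c1`: compound 3 gives 40200 nM.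

Compound 1 stands at the limit (the limit of >= 204000 nM in this assay, at which 1 of the 3 values shown sits); its true value is not pinned down, only bounded. Compound 4 `Cc1cc(C)c(Oc2cc(Nc3ccc(C#N)cc3)ncc2C(=O)NCc2cn(Cc3cccc(C#N)c3)nn2)c(C)c1` differs from compound 1 only in one spot: cyano in place of fluoro on an aromatic carbon. Going by the values given here, no measured pair shows this exact swap. The measured steps replace the whole 3-fluorophenyl with a chain, giving an at least 9.4-fold lower number from compound 1 to compound 2 (0.97 log units; beyond the scatter) and an at least 5.0-fold lower number from compound 1 to compound 3 (0.70 log units; beyond the scatter), while the swap of cyano for ethoxycarbonyl on a chain, a 1.9-fold higher number from compound 2 to compound 3 (0.27 log units; within the scatter), stays within the scatter. Among the compounds with values here, since the 3-fluorophenyl is kept in compound 4 and only one small group on it changes, compound 4 is expected to stay close to compound 1, most likely at the limit again, with a step of an at least 1.0-fold lower number from compound 1 to compound 4 (0.03 log units; that floor lies within the scatter). Compound 4 is therefore estimated at 190000 nM, in a range from 70000 nM to 300000 nM.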

Compound 4, half-maximal cytotoxic concentration: >= 129000 nM
Compound 4 ended at the assay's limit; the forecaster's own chance of this, stated with the estimate: 60%; the middle value does not contradict the limit.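

In this assay compound 4 ends at a limit and not at a measured number: the limit of >= 129000 nM in this assay, at which 1 of the 4 values shown sits.

Compound 1 is also only a limit, so the step from fluoro to cyano cannot be read: the limit of >= 204000 nM in this assay, at which 1 of the 4 values shown sits.

What is new is that the high reading is not confined to the 3-fluorophenyl group: the 3-cyanophenyl group also stands clear of both chain compounds, with an at least 3.2-fold higher number from compound 3 to compound 4 (0.50 log units; beyond the scatter) and an at least 6.0-fold higher number from compound 2 to compound 4 (0.77 log units; beyond the scatter), so among these four compounds the two carrying a substituted phenyl ring give the higher numbers.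

From the compounds shown here alone, how far compound 1 and compound 4 each lie past their limits remains open, so fluoro and cyano cannot be placed in order. Also open, going by these compounds, is how an amine or a carboxylic acid in place of the fluoro would read in this assay.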